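This account rests on a few compounds, and the source may have more. Where it says the series, first, only, none or still open, it means among the compounds named here.

Measured in a functional assay on THP-1 cells (Homo sapiens) for cytotoxicity, read by MTT assay, with a stated time of 24 h; on this read-out lower numbers stand for stronger inhibition and higher numbers for weaker inhibition:
Compound 1 `CN1C/C(=C\c2ccc(C#N)cc2)C(=O)/C(=C/c2ccccc2F)C1`: 810 nM
Compound 2 `COc1cc(/C=C2\CN(C)C/C(=C\c3ccc(F)cc3)C2=O)cc(OC)c1`: 5040 nM
Compound 3 `COc1cc(/C=C2\CN(C)C/C(=C\c3ccc(F)cc3)C2=O)cc(OC)c1OC`: 6130 nM

Compound 3, at 6130 nM, lies within the scatter of compound 2, at 5040 nM. Both numbers stand well above that of compound 1, at 810 nM.

Compound 4 `COc1cc(/C=C2\CN(C)C/C(=C\c3cccc([N+](=O)[O-])c3)C2=O)cc(OC)c1OC` keeps the rest of compound 3 and changes one group: 3-nitrophenyl in place of 4-fluorophenyl on a double-bonded chain carbon bound to a double-bonded ring carbon. In words, 3-nitrophenyl stands in place of 4-fluorophenyl on a double-bonded chain carbon bound to a double-bonded ring carbon.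

For the measured compounds named here, only one measured step is available, a 1.2-fold higher number from compound 2 to compound 3 (0.09 log units; within the scatter). It is methoxy in place of hydrogen on an aromatic carbon, so it shows how little that edit moved the number in this assay, but it does not touch the place that changes here. Going by the values given here, no measured step isolates this swap. Compound 1, at 810 nM, shows that a lower number occurs in this small set, yet it differs from compound 3 in more than one place and gives only weak support. A small drift toward a lower number is therefore expected, with no firm step beyond the scatter. The expected change is a 1.8-fold lower number from compound 3 to compound 4 (0.24 log units; within the scatter). The estimate for compound 4 is 3500 nM, with an expected range from 1100 nM to 9000 nM.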

Compound 4, half-maximal inhibitory concentration: 890 nM
Compound 4: middle estimate off by 3.9-fold (0.59 log units), on the high side; the whole stated range lies above it.
By their numbers in this assay, from the lowest: compounds 1 and 4 (each within the scatter of the next); then compounds 2 and 3 (each within the scatter of the next).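

In this assay, 3-nitrophenyl in place of 4-fluorophenyl on a double-bonded chain carbon bound to a double-bonded ring carbon gives a 6.9-fold lower number from compound 3 to compound 4 (0.84 log units; beyond the scatter), so this position can move the number well beyond the scatter. The only earlier step, methoxy in place of hydrogen on an aromatic carbon, was a 1.2-fold higher number from compound 2 to compound 3 (0.09 log units; within the scatter), and it left open whether any single edit in this series would register in this assay; the present swap is the first one shown that does. Nothing available explains the size of this step or ties it to any property of either group.

The compounds shown leave open whether the lower number belongs to the nitro group itself or to where it sits on the phenyl ring, as this one swap alters both the group and its place at once. They also leave open how an amine or a carboxylic acid on that phenyl ring would read at this position, and whether the swap would give a step of similar size on a differently substituted partner ring.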